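The source may report more compounds than this note shows. Statements on the series, on what has been measured and on what is new or still open speak of the compounds shown alone.

Measured compounds:
Compound 1, `Fc1cccc(F)c1C#Cc1cnc2ccccc2c1`: 90.4%
Compound 2, `Fc1cccc(F)c1C#Cc1cnc2ccccc2c1Cl`: 80.4%
Compound 3, `Fc1cccc(F)c1C#Cc1ccc2ncccc2c1`: 80.1%

All three were tested in a functional assay on LS174T cells (Homo sapiens) for inhibition, with a stated time of 4 days, tested at 10 uM; a higher number here means a stronger effect of the compound at the concentration tested, a lower number a weaker effect. Compound 2 differs from compound 1 by chloro in place of hydrogen on an aromatic carbon, and this gave a number 10 percentage points lower from compound 1 to compound 2 (within the scatter). Compound 3 shares its atoms with compound 1 but joins them differently; the difference between the two cores is not broken down here. Its value in this assay lies below that of compound 1 by more than the scatter, while compound 3 and compound 2 give numbers that fall within the scatter of each other.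

Compound 4, `Fc1cccc(F)c1C#Cc1ccc2nc(Cl)ccc2c1`, has not yet been measured. It differs from compound 3 by chloro in place of hydrogen on an aromatic carbon. Going by the values given here, this is the same kind of change as the one from compound 1 to compound 2, but not the same: in compound 2 the chloro sits ortho to a fused ring, ortho to a large group, meta to a fused ring and opposite the ring nitrogen, whereas in compound 4 it sits next to the ring nitrogen, meta to a fused ring and para to a fused ring.

Among the compounds with values here, the only guide is the earlier step, so a step of similar size is expected, a number 8.1 percentage points lower from compound 3 to compound 4 (within the scatter), because a number 10 percentage points lower from compound 1 to compound 2 (within the scatter) was within the scatter. Compound 4 is therefore estimated to give 72% in this assay, with a likely range from 57% to 85%.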

Compound 4, a percentage reported as inhibition, at one concentration (the size of the read-out at that concentration, not a potency): 63.3%
The estimate for compound 4 lay 8.7 percentage points above the measured number; the range from low to high includes it.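

In this assay, chloro in place of hydrogen on an aromatic carbon gave a number 16.8 percentage points lower from compound 3 to compound 4 (beyond the scatter), with the chloro next to the ring nitrogen of the core of compound 3. Set beside the earlier step, the change lowers the number on both cores, and the two steps cannot be told apart in size: the same change on two cores in this assay, a number 10 percentage points lower (within the scatter) from compound 1 to compound 2 and a number 16.8 percentage points lower (beyond the scatter) from compound 3 to compound 4, 6.8 percentage points apart, within the scatter of two such steps. This shows only that, across these two pairs, the direction of the change carried over from one core to the other, but it does not show a rule for other cores, and since the chloro occupies a different place in each core, the effect of the place cannot be separated from that of the core, while a read-out at a single concentration says nothing about potency.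

The compounds shown leave open how a methyl, an amine or a carboxylic acid in place of the chloro would read on either core. They also leave open whether chloro at a further position on the same core would follow these two steps, or whether a longer chain there would lower the number as well.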